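This account rests on a few compounds, and the source may have more. Where it says the series, first, only, none or still open, it means among the compounds named here.

Measured compounds in a functional assay on BGC-823 cells (Homo sapiens) for antiproliferative activity, read by MTT assay, tested at 5 uM; a lower number here means a weaker effect, a higher number a stronger effect of the compound at the concentration tested: compound 1, `COc1cc(C(=O)N/N=C/c2cccc(F)c2)cc(OC)c1OC`, 44.8%; compound 2, `COc1cc(C(=O)N/N=C/c2c(Cl)cccc2Cl)cc(OC)c1OC`, 27.8%; compound 3, `COc1cc(C(=O)N/N=C/c2ccccc2F)cc(OC)c1OC`, 76.5%.

Compound 3 stands highest of the three numbers in this assay. Its nearest neighbour is compound 1, with a number 31.7 percentage points higher from compound 1 to compound 3 (beyond the scatter), and the furthest is compound 2, with a number 48.7 percentage points higher from compound 2 to compound 3 (beyond the scatter), both beyond the scatter.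

Compound 4, `COc1cc(C(=O)N/N=C/c2cc(Cl)cc(Cl)c2)cc(OC)c1OC`, has not yet been measured. It differs from compound 3 in one place: 3,5-dichlorophenyl in place of 2-fluorophenyl on a carbon with a double bond to nitrogen.

For the measured compounds named here, two measured steps bear on this change. Moving from a 2-fluorophenyl to a 3-fluorophenyl on the carbon with a double bond to nitrogen gave a number 31.7 percentage points higher from compound 1 to compound 3 (beyond the scatter) in reverse, a large fall. Replacing a 3-fluorophenyl by a 2,6-dichlorophenyl gave a number 17 percentage points lower from compound 1 to compound 2 (beyond the scatter), a modest fall. Both point the same way: chlorines and halogens away from the pattern of compound 3 have lowered the number. As far as these compounds go, compound 4 combines both features, so a large fall from compound 3 is expected, though the exact 3,5-dichlorophenyl pattern is untested here. Compound 4 is therefore expected to give 38% in this assay, within 20% to 58%, corresponding to an expected step of a number 38.5 percentage points lower from compound 3 to compound 4 (beyond the scatter).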

Compound 4, a percentage reported as inhibition, at one concentration (the size of the read-out at that concentration, not a potency): 9.2%
The estimate for compound 4 lay 28.8 percentage points above the measured number, outside the stated range (below it).
By their numbers in this assay, from the lowest: compound 4; then compound 2; then compound 1; then compound 3.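

In this assay the 3,5-dichlorophenyl on the carbon with a double bond to nitrogen gives the lowest number of the four compounds, with a number 67.3 percentage points lower from compound 3 to compound 4 (beyond the scatter) and a number 35.6 percentage points lower from compound 1 to compound 4 (beyond the scatter). The earlier compounds showed that the number at this place differs between 2-fluorophenyl and 3-fluorophenyl and that 2,6-dichlorophenyl stands lower than both, whereas the new result shows that the two dichlorophenyl groups also differ from each other, with a number 18.6 percentage points lower from compound 2 to compound 4 (beyond the scatter), so that among these four compounds both dichlorophenyl compounds stand below both fluorophenyl compounds and the placing of the chlorines still moves the number. Nothing available here accounts for why this change lowers the number.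

As far as these compounds go, what a phenyl carrying a single chlorine, a methoxy group, an amine or a carboxylic acid would give at this place remains open, as does whether any such group could match or pass compound 3. All four compounds share the same core and are read at one concentration, so the effect of changes elsewhere on the core and the potency of these compounds also stay unresolved.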